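A few compounds are considered here, and "the series" means these few. Any claim that something is new, unique, unknown or untested is made for them only; others in the source may bear on it.

Compound 1 `Cc1cc(=O)c2c(O)cc(OCc3ccccc3)c([C@H]3CCN(C)C[C@H]3O)c2o1`: 14%
Compound 2 `Cc1cc(=O)c2c(O)cc(O)c([C@H]3CCN(C)C[C@H]3OC(=O)c3ccco3)c2o1`: 13%
Compound 3 `Cc1cc(=O)c2c(O)c(CN(C)CC(=O)O)c(O)c([C@H]3CCN(C)C[C@H]3O)c2o1`: 16%

These values come from a functional assay on MIA PaCa-2 cells (Homo sapiens) for inhibition, read by MTT assay, with a stated time of 48 h, tested at 10 uM; a lower number here means less inhibition of growth, a higher number more inhibition of growth at the concentration tested. Compound 3, at 16%, stands level with compound 1 and compound 2, since all three numbers lie within the usual scatter of each other.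

Compound 4 `Cc1cc(=O)c2c(O)c(CN3CCCCC3)c(O)c([C@H]3CCN(C)C[C@H]3O)c2o1` differs from compound 3 in one place: piperidin-1-yl in place of (carboxymethyl)(methyl)amino on a saturated chain carbon bound to an aromatic carbon. Piperidin-1-yl takes the place of (carboxymethyl)(methyl)amino on a saturated chain carbon bound to an aromatic carbon.

Among the compounds with values here, no pair of measured compounds shows this exchange, so the expectation rests on compound 3 at 16%. In this assay, no change beyond the scatter is expected, and the estimated a number 4 percentage points higher from compound 3 to compound 4 (within the scatter) is small and upward. Compound 4 is expected at 20%, within an estimated range of 8% to 38%.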

Compound 4, percent growth inhibition at one concentration: 14%
The estimate for compound 4 lay 6 percentage points above the measured number; the measured number falls inside the stated range.
By their numbers in this assay, from the lowest: compounds 2, 1, 4 and 3 (each within the scatter of the next).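

Exchanging (carboxymethyl)(methyl)amino for piperidin-1-yl on a saturated chain carbon bound to an aromatic carbon gives a number 2 percentage points lower from compound 3 to compound 4 (within the scatter) in this assay. Within the data shown here, this is the first direct reading at this position: an open chain with a carboxylic acid and a six-membered non-aromatic ring without one read alike here. No available measurement explains this result. The compounds shown leave open whether a morpholin-4-yl ring, a primary amine or a longer chain at this place would separate from these values, and the two groups compared here say nothing about those.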